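A few compounds are considered here, and "the series" means these few. Any claim that something is new, unique, unknown or untested is made for them only; others in the source may bear on it.

Of the compounds shown here, two of a shared core have been measured in a functional assay on KG-1a cells (Homo sapiens) for inhibition, read by MTT assay, with a stated time of 72 h; on this read-out higher numbers stand for weaker inhibition and lower numbers for stronger inhibition. Compound 1 `Cc1ccc(-c2nnc(-c3ccc(CN4CCN(C)CC4)c(C(F)(F)F)c3)o2)cc1Nc1nccc(-c2cccnc2)n1` gives 580 nM. Compound 2 `Cc1nnc(-c2ccc(C)c(Nc3nccc(-c4cccnc4)n3)c2)o1` gives 18000 nM, the higher of the two numbers, so compound 2 stands as the weaker inhibitor of the pair. Compound 3 `Cc1ccc(-c2nnc(-c3ccc(F)c(C(F)(F)F)c3)o2)cc1Nc1nccc(-c2cccnc2)n1` has not yet been measured. It differs from compound 2 by 4-fluoro-3-(trifluoromethyl)phenyl in place of methyl on an aromatic carbon. Compound 1 carries a related aryl group at that same position and gives 580 nM, so the step from compound 2 to compound 3 is expected to move the number downward, toward stronger inhibition, by an amount well beyond the scatter, a 15-fold lower number from compound 2 to compound 3 (1.18 log units; beyond the scatter). Compound 3 is therefore estimated at 1200 nM in this assay, with a likely range from 300 nM to 5000 nM.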

Compound 3, half-maximal inhibitory concentration: > 30000 nM
Compound 3 ended at the assay's limit; the forecaster's own chance of this, stated with the estimate: 5%; middle value at least 25-fold (1.39 log units) from the limit.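

In this assay compound 3 sits at the top of the measurable range, so its entry is a limit and not a number: the limit of > 30000 nM in this assay, at which 1 of the 3 values shown sits. Swapping the small methyl for the much larger aryl group gives an at least 1.6-fold higher number from compound 2 to compound 3 (0.22 log units; that floor lies within the scatter), so a 4-fluoro-3-(trifluoromethyl)phenyl group at this position brings no gain in inhibition over methyl. For the compounds shown here, the single change on that aryl ring gives an at least 51-fold higher number from compound 1 to compound 3 (1.71 log units; beyond the scatter), which shows that in this pair the stronger inhibition goes with the (4-methylpiperazin-1-yl)methyl group and not with the aryl ring alone.

Going by these compounds, what remains open is whether the whole piperazine is needed, or whether a smaller amine such as dimethylaminomethyl would serve in the same place. A morpholine or a carboxylic acid there would also test how specific this effect is.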